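The source may report more compounds than this note shows. Statements on the series, on what has been measured and on what is new or still open speak of the compounds shown alone.

Measured in a functional assay on B16-F0 cells (Mus musculus) for inhibition, read by CCK-8 assay, with a stated time of 48 h; a higher number here means a weaker inhibitor, a lower number a stronger inhibitor:

- compound 1 `Cn1ccc2cc(-c3cc4nccc(-c5ccc(F)cc5)n4n3)ccc21`: 4780 nM.
- compound 2 `COc1ccc(-c2cc3nccc(-c4cc(OC)c(OC)c(OC)c4)n3n2)cc1[N+](=O)[O-]`: > 10000 nM.
- compound 3 `COc1cc(-c2ccnc3cc(-c4ccccc4)nn23)cc(OC)c1OC`: 4730 nM.

Compound 2 gives > 10000 nM, which is a limit of this assay rather than a number (the limit of > 10000 nM in this assay, at which 1 of the 3 values shown sits). Of the two numbers, compound 3 holds the lower one, but compound 1 sits within the scatter of it, so neither stands apart from the other.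

Compound 4 `COc1cc(-c2ccnc3cc(-c4ccc(C(F)(F)F)cc4)nn23)cc(OC)c1OC` remains to be measured. It differs from compound 3 in one place: trifluoromethyl in place of hydrogen on an aromatic carbon. For the measured compounds named here, no measured pair in this set shows the effect of such a change, so the expectation leans on compound 3 alone. The step from compound 3 to compound 4 in this assay is expected to be a 1.2-fold lower number from compound 3 to compound 4 (0.07 log units; within the scatter), not clearly beyond the scatter in either direction. Compound 4 is therefore estimated at 4000 nM, within a range from 1200 nM to 13000 nM.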

Compound 4, half-maximal inhibitory concentration: 1770 nM
Compound 4: middle estimate off by 2.3-fold (0.35 log units), on the high side, and the stated range covers the measured number.
By their numbers in this assay, from the lowest: compound 4; then compounds 3 and 1 (each within the scatter of the next). At a limit, above all of these: compound 2.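

In this assay, trifluoromethyl in place of hydrogen on an aromatic carbon, para to a large group, gives a 2.7-fold lower number from compound 3 to compound 4 (0.43 log units; beyond the scatter). For the compounds shown here, this is the first single-place step, and it shows that this position of the phenyl ring responds to substitution and accepts trifluoromethyl without loss. Nothing shown here gives a reason for this step.

On these data alone, whether the response is specific to trifluoromethyl remains open, as an amine or a carboxylic acid at this position would test. Also open, as far as these compounds go, is whether the same change carries over to other substituents on the shared core.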